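Sulfonamide series: tosylamide aryl pyrazoles and hydrazide, cytotoxicity notes

A few compounds are considered here, and "the series" means these few. Any claim that something is new, unique, unknown or untested is made for them only; others in the source may bear on it.

Measured compounds:
- compound 1, `C/C(=N/NC(=O)C(C#N)C(=S)S)c1ccc(NS(=O)(=O)c2ccc(C)cc2)cc1`: 11000 nM
- compound 2, `Cc1ccc(S(=O)(=O)Nc2ccc(-c3cc(-c4ccc([N+](=O)[O-])cc4)n(C(N)=S)n3)cc2)cc1`: "not active" (no number reported)

In a functional assay on HepG2 cells (Homo sapiens) for cytotoxicity, read by sulforhodamine B assay, with a stated time of 48 h (a higher number here means a weaker inhibitor, a lower number a stronger inhibitor), compound 1 gives 11000 nM. In this assay compound 2 gives "not active" (no number reported), so no single number stands against compound 2; the only thing its record shows is the absence of a measurable response, and nothing can be said about how far it lies from compound 1.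

Compound 3, `Cc1ccc(S(=O)(=O)Nc2ccc(-c3cc(-c4ccc([N+](=O)[O-])cc4)n(-c4ccccc4)n3)cc2)cc1`, keeps the core of compound 2 and differs from it in one place: a group of 6 heavy atoms (6 carbon; one six-membered aromatic ring of carbon only) in place of a group of 3 heavy atoms (1 carbon, 1 nitrogen, 1 sulfur; no ring), on an aromatic nitrogen. Within the data shown here, no step between two measured compounds is recorded for this series, so there is no measured change from which to read the size of this one. For compound 3 the expectation in this assay is therefore weak activity, with a real chance that only a limit is reported, as for compound 2; a direction relative to compound 2 cannot be stated, since compound 2 has no number.

The estimated value for compound 3 is 30000 nM, with an expected range from 8000 nM to 100000 nM.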

Compound 3, half-maximal inhibitory concentration: "not active" (no number reported)
No number was reported for compound 3, so the estimate cannot be set against anything.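

In this assay compound 3 gives "not active" (no number reported) and compound 2 gives "not active" (no number reported), so no step can be read between these two compounds. The compounds shown leave open how far phenyl on the aromatic nitrogen shifts cytotoxicity relative to the group it replaces in compound 2. No supporting evidence bears on this result.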